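The source may hold more compounds than are shown below. What is called first, only, known or untested is meant among the compounds shown, and "the series" means these compounds.

Compound 1 `O=C(Nc1ccccc1)Nc1cccc(CNc2nccnc2Cl)c1` — 16300 nM
Compound 2 `COc1ccccc1NC(=O)Nc1cccc(CNc2nccnc2Cl)c1` — 12200 nM
Compound 3 `Cc1ccccc1NC(=O)Nc1cccc(CNc2nccnc2Cl)c1` — 14000 nM

In a functional assay on MGC-803 cells (Homo sapiens) for antiproliferative activity, read by MTT assay, with a stated time of 48 h (on this read-out lower numbers stand for stronger inhibition and higher numbers for weaker inhibition), compound 1 gives the highest of the three numbers shown, yet both steps away from it stay within the scatter: a 1.3-fold lower number from compound 1 to compound 2 (0.13 log units; within the scatter) and a 1.2-fold lower number from compound 1 to compound 3 (0.07 log units; within the scatter). Compound 4 `Cc1ccc(NC(=O)Nc2cccc(CNc3nccnc3Cl)c2)cc1Cl` differs from compound 1 by 3-chloro-4-methylphenyl in place of phenyl on an amide-type nitrogen. The two measured steps bear on this only loosely: each placed a single group on an aromatic carbon of the same core and neither moved the number beyond the scatter. Going by the values given here, no measured step covers chlorine, and none covers two groups entering together. For compound 4 the expected step is therefore a 1.5-fold lower number from compound 1 to compound 4 (0.17 log units; within the scatter), no larger than the scatter around compound 1. Compound 4 is estimated at 11000 nM, range 3500 nM to 30000 nM.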

Compound 4, half-maximal inhibitory concentration: 17500 nM
Beside the measured number, compound 4's estimate is 1.6-fold (0.20 log units) below it, within the range that was stated.
By their numbers in this assay, from the lowest: compounds 2, 3, 1 and 4 (each within the scatter of the next).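

In this assay two groups entering together at this amide-type nitrogen stay within the scatter, as a single group did: the readings are (a 1.1-fold higher number from compound 1 to compound 4 (0.03 log units; within the scatter)), (a 1.3-fold higher number from compound 3 to compound 4 (0.10 log units; within the scatter)) and (a 1.4-fold higher number from compound 2 to compound 4 (0.16 log units; within the scatter)). So 3-chloro-4-methylphenyl, the first chlorine-bearing group here, cannot be told apart from phenyl, 2-methylphenyl or 2-methoxyphenyl. No evidence is available on why the number stays so flat at this position.

Still open, on these data alone, is whether an amine or a carboxylic acid on this ring would move the number beyond the scatter. As far as these compounds go, whether any change to the shared core would do so also remains open.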